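A few compounds are considered here, and "the series" means these few. Any claim that something is new, unique, unknown or untested is made for them only; others in the source may bear on it.

Measured compounds: compound 1 `Nc1ccccc1NC(=O)c1ccc(CSC(=S)N2CCN(c3cccnc3)CC2)cc1`, compound 2 `Nc1ccccc1NC(=O)c1ccc(CSC(=S)N2CCc3cc(Cl)ccc32)cc1`, compound 3 `CC1CCN(C(=S)SCc2ccc(C(=O)Nc3ccccc3N)cc2)CC1`.

In a functional assay on MGC-803 cells (Homo sapiens) for antiproliferative activity, read by CCK-8 assay, with a stated time of 72 h, tested at 8 uM (on this read-out lower numbers stand for a weaker effect and higher numbers for a stronger effect at the one concentration tested), compound 1 gives 76.9%, the lowest of the three numbers, though compound 2 with 82.2% and compound 3 with 81.9% both stand within the scatter of it. Among the compounds with values here, the one step recorded between measured compounds, a number 0.3 percentage points lower from compound 2 to compound 3 (within the scatter), changes the group on the thiocarbonyl carbon and says nothing about the aryl on the ring nitrogen. Compound 4 `Nc1ccccc1NC(=O)c1ccc(CSC(=S)N2CCN(c3ccccc3F)CC2)cc1` differs from compound 1 by 2-fluorophenyl in place of pyridin-3-yl on an amine nitrogen in a ring. Within the data shown here, no measured step bears on this exchange, so no step beyond the scatter is expected in this assay, and the step from compound 1 to compound 4 is estimated at a number 1.1 percentage points higher from compound 1 to compound 4 (within the scatter). Compound 4 is expected to give about 78%, between 66% and 88%.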

Compound 4, a percentage reported as inhibition, at one concentration (the size of the read-out at that concentration, not a potency): 86.4%
Beside the measured number, compound 4's estimate is 8.4 percentage points below it; measured number inside the range.
By their numbers in this assay, from the lowest: compounds 1, 3, 2 and 4 (each within the scatter of the next).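

In this assay, the exchange on the amine nitrogen in the ring gives a number 9.5 percentage points higher from compound 1 to compound 4 (within the scatter), the first step read at this position. Pyridin-3-yl and 2-fluorophenyl, which differ in the ring hetero atom and the fluorine, therefore remain within the scatter of each other at this place, at this one concentration. No evidence on hand gives a reason for this step.

As far as these compounds go, whether a carboxylic acid or a dimethylamino group on the aryl ring would also stay within the scatter remains open. So does the effect of a plain methyl group in place of the aryl on this nitrogen.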